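A few compounds are considered here, and "the series" means these few. Any claim that something is new, unique, unknown or untested is made for them only; others in the source may bear on it.

Compound 1 `COc1cc(/C=C/C(=O)OCCCCCCO[N+](=O)[O-])ccc1O`: 16300 nM
Compound 2 `O=C(/C=C/c1ccc(OCCCCCCO[N+](=O)[O-])c(O)c1)OCCCCCCO[N+](=O)[O-]`: 1350 nM

In a functional assay on HeLa cells (Homo sapiens) for cytotoxicity, read by resazurin assay, with a stated time of 72 h (a lower number here means a stronger inhibitor, a higher number a weaker inhibitor), compound 2 has the lower of the two numbers, at 1350 nM, and the number for compound 1 lies above it, beyond the scatter. Compound 3 `COc1cc(/C=C/C(=O)OCCCCCCO[N+](=O)[O-])ccc1OCCCCCCO[N+](=O)[O-]` differs from compound 2 in one place: methyl in place of hydrogen on an oxygen on an aromatic ring, a methyl in place of hydrogen on an oxygen on an aromatic ring, so hydroxy becomes methoxy. Among the measured compounds shown here, no measured pair shows this change alone, so only a small step toward a higher number is expected, possibly none beyond the scatter. The estimate for compound 3 is 2000 nM, with an expected range of 700 nM to 6000 nM.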

Compound 3, half-maximal inhibitory concentration: > 50000 nM
Compound 3 ended at the assay's limit (the forecaster's own chance of this, stated with the estimate: 3%); middle value at least 25-fold (1.39 log units) away from the limit.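

In this assay, methyl in place of hydrogen on an oxygen on an aromatic ring gives an at least 37-fold higher number from compound 2 to compound 3 (1.56 log units; beyond the scatter), while 6-(nitrooxy)hexyl in place of hydrogen on such an oxygen gives an at least 3.0-fold higher number from compound 1 to compound 3 (0.48 log units; beyond the scatter). Compound 3 reads > 50000 nM, which is a limit of the assay and not a number. Each step replaces the only hydroxy of its starting compound, so a small methyl is enough to produce a large step, and compound 3 alone carries no hydroxy. Still open is whether that hydrogen itself matters, since an amine in place of the hydroxy is not among these compounds.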